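The source may report more compounds than this note shows. Statements on the series, on what has been measured and on what is new or still open speak of the compounds shown alone.

Compound 1 `CNc1nc(NC2(C#N)CCCCC2)nc(-n2cnc(C)n2)n1`, compound 2 `CNc1nc(NC2(C#N)CCCCC2)nc(C2CC2)n1`, compound 3 `CNc1nc(NC2(C#N)CCCCC2)nc(N2CCCC2)n1`.

In an in vitro assay on Sf21 cells for inhibition of high affinity 3',5'-cyclic-AMP phosphodiesterase 7A (Homo sapiens) (on this read-out lower numbers stand for stronger inhibition and higher numbers for weaker inhibition), compound 2 gives 539 nM. For compound 1 the value > 5000 nM is a limit of this assay, not a number. For compound 3 the value > 5000 nM is likewise a limit. Compound 1 therefore stands only at the limit, (the limit of > 5000 nM in this assay, at which 2 of the 3 values shown sit).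

Compound 4 `CNc1nc(NC2CCCC2)nc(NC2(C#N)CCCCC2)n1` differs from compound 1 in one place: cyclopentylamino in place of 3-methyl-1H-1,2,4-triazol-1-yl on an aromatic carbon. Within the data shown here, two measured steps bear on this. an at least 9.2-fold lower number from compound 1 to compound 2 (0.96 log units; beyond the scatter), whereas a step that the two limits leave unreadable from compound 1 to compound 3; consistent with that, an at least 9.2-fold higher number from compound 2 to compound 3 (0.96 log units; beyond the scatter). The entering cyclopentylamino resembles the pyrrolidin-1-yl of compound 3 more than the cyclopropyl of compound 2, so no gain beyond the scatter is expected. Compound 4 is estimated at 4000 nM, between 800 nM and 20000 nM, which would mean an at least 1.2-fold lower number from compound 1 to compound 4 (0.09 log units; that floor lies within the scatter).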

Compound 4, half-maximal inhibitory concentration: > 5000 nM
Compound 4: no number, only a limit (the forecaster's own chance of this, stated with the estimate: 55%); middle value at least 1.2-fold (0.09 log units) from the limit.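

Compound 4 also stands only at a limit, the third of the compounds shown to do so: the limit of > 5000 nM in this assay, at which 3 of the 4 values shown sit. Cyclopentylamino in place of cyclopropyl gives an at least 9.2-fold higher number from compound 2 to compound 4 (0.96 log units; beyond the scatter), so a nitrogen-linked ring with a hydrogen-bond donor on this aromatic carbon, opposite the ring nitrogen, does not reach the level of compound 2, while the steps from compound 1 and compound 3 to compound 4 cannot be read. From the compounds shown here alone, how far compound 1, compound 3 and compound 4 differ among themselves remains open. Also open, going by these compounds, is whether other carbon-linked groups, such as a cyclobutyl, an isopropyl or a phenyl, would match or pass the cyclopropyl of compound 2.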